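Swapping an Aromatic Ring for a Cyclohexyl Ring

The source may report more compounds than this note shows. Statements on the series, on what has been measured and on what is new or still open speak of the compounds shown alone.

Among the measured compounds shown here, in a functional assay on SK-BR-3 cells (Homo sapiens) for cytotoxicity, read by MTT assay, with a stated time of 72 h (a lower number here means a stronger inhibitor, a higher number a weaker inhibitor), compound 3 `Nc1ccc(Nc2c(C(=O)NCc3ccc(F)cc3)nc(Br)c3cccnc23)cc1` gives 4000 nM, the lowest of the two numbers available so far. Compound 1 `N[C@H]1CC[C@H](Nc2c(C(=O)NCc3ccco3)nc(Br)c3cccnc23)CC1` gives 10000 nM, a higher number by a gap beyond the scatter of repeated measurements. For compound 2 `N[C@H]1CC[C@H](Nc2c(C(=O)NCc3ccc(Oc4ccccc4)cc3)nc(Br)c3cccnc23)CC1` the entry reads "not determined" (no result reported), so it adds nothing to the comparison.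

Compound 4 `N[C@H]1CC[C@H](Nc2c(C(=O)NCc3ccc(F)cc3)nc(Br)c3cccnc23)CC1` matches compound 3 except for one group: 4-aminocyclohexyl in place of 4-aminophenyl on a nitrogen on an aromatic ring, (4-aminocyclohexyl in place of 4-aminophenyl on a nitrogen on an aromatic ring). For the measured compounds named here, no two measured compounds differ in only one place, so the effect of this swap cannot be read directly from the data. Going by the values given here, the only clue is compound 1, which carries the same 4-aminocyclohexyl group and gives 10000 nM, although its other side group is not the one in compound 4. This points weakly towards a slightly higher number. The estimated step is a 1.3-fold higher number from compound 3 to compound 4 (0.10 log units; within the scatter), which is expected to stay within the scatter. For compound 4 the expected value is 5000 nM, with an estimated range from 1500 nM to 15000 nM.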

Compound 4, half-maximal inhibitory concentration: 2000 nM
Compound 4: the middle estimate sits 2.5-fold (0.40 log units) above what was measured; the range from low to high includes it.
By their numbers in this assay, from the lowest: compounds 4 and 3 (each within the scatter of the next); then compound 1.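

In this assay the swap on the nitrogen gives a 2.0-fold lower number from compound 3 to compound 4 (0.30 log units; within the scatter), so a non-aromatic ring of carbon and an aromatic ring of carbon cannot be told apart at this position. Among the compounds shown here, the result also gives the first reading of the other side group, where holding 4-aminocyclohexyl fixed and placing 4-fluorophenyl in place of furan-2-yl gives a 5.0-fold lower number from compound 1 to compound 4 (0.70 log units; beyond the scatter), and this change, unlike the ring swap, clears the scatter. Nothing measured here offers a reason for either step.

The compounds shown leave open whether the amine on the ring matters, as a hydroxyl group or a carboxylic acid in its place would show. They also leave open how a longer chain between that amine and the nitrogen on the aromatic ring would compare.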